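A few compounds are considered here, and "the series" means these few. Any claim that something is new, unique, unknown or untested is made for them only; others in the source may bear on it.

Measured in a functional assay on MDA-MB-231 cells (Homo sapiens) for cytotoxicity, read by neutral red uptake, with a stated time of 72 h; a higher number here means a weaker inhibitor, a lower number a stronger inhibitor:

compound 1, `CCCNc1nc(NCCC)c2ccccc2n1`: 4430 nM
compound 2, `CCCCNc1nc(SCC)nc2ncccc12`: 9200 nM
compound 3, `CCCCCNc1nc(SCC)nc2ncccc12`: 1300 nM

Compound 3 stands lowest of these three numbers. Compound 1 is nearest to it and compound 2 furthest, and both gaps lie beyond the scatter of this assay, so compound 3 is the strongest inhibitor of the three. Compound 4, `CCCCCCCNc1nc(SCC)nc2ncccc12`, has not yet been measured. It differs from compound 3 by ethyl in place of hydrogen on a saturated chain carbon, five bonds along the chain from a nitrogen on an aromatic ring, that is, the chain on the nitrogen grows by two carbons while the rest of the molecule stays the same.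

For the measured compounds named here, one measured step bears on this: the chain on the same nitrogen was already lengthened once, and a 7.1-fold lower number from compound 2 to compound 3 (0.85 log units; beyond the scatter). Going by the values given here, compound 1 has a different core and no single-point step to the others, so it gives no guidance here. A further lengthening of the same chain is therefore expected to lower the number again in this assay, though on a single step the size is uncertain and a smaller change than before is likely. The expected step is a 1.9-fold lower number from compound 3 to compound 4 (0.27 log units; within the scatter). Compound 4 is thus estimated at 700 nM, with a range from 200 nM to 3000 nM.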

Compound 4, half-maximal inhibitory concentration: 2600 nM
Estimate against measurement, compound 4: 3.7-fold (0.57 log units) below; the measured number falls inside the stated range.
By their numbers in this assay, from the lowest: compounds 3, 4 and 1 (each within the scatter of the next, the first and the last beyond it); then compound 2.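

In this assay the gain seen on the first lengthening of this chain does not carry on, with a 2.0-fold higher number from compound 3 to compound 4 (0.30 log units; within the scatter) and so no real difference between these two compounds. The longer chain still keeps a clear advantage over the shorter one, with a 3.5-fold lower number from compound 2 to compound 4 (0.55 log units; beyond the scatter) marking a gap beyond the usual scatter, so across compounds 2, 3 and 4 the number falls once and then levels off rather than falling steadily. Nothing available explains why the trend levels off at this position.

As far as these compounds go, with only these three chain lengths on the shared core, it remains open whether a still longer chain would hold this level or lose it, and whether a branched chain or a chain ending in an amine or a carboxylic acid would behave differently. From the compounds shown here alone, it is also open whether the same chain change would have a similar effect on the core of compound 1, or with a group other than the ethyl on sulfur that compounds 2, 3 and 4 all carry.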